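Enantiomer swap at the benzylic stereocentre

The source may report more compounds than this note shows. Statements on the series, on what has been measured and on what is new or still open speak of the compounds shown alone.

Compound 3 `C[C@@H](NC(=O)Nc1ccc(F)cc1)c1ccccc1` in an ADME assay on the whole organism with Oryza sativa as the target, tested at 10 uM (a lower number here means a stronger effect, a higher number a weaker effect of the compound at the concentration tested), gives 92%. Compound 2 `CCOC(=O)c1ccc(NC(=O)N[C@@H](C)c2ccccc2)cc1` gives 92%, level with compound 3 at the digits shown. Among the compounds with values here, compound 1 `CCCCc1ccc(NC(=O)N[C@@H](C)c2ccccc2)cc1` gives 60%, the lowest of the three; the one measured step, a number 32 percentage points higher from compound 1 to compound 2 (beyond the scatter), concerns the aromatic substituent, not the stereocentre. Compound 4 `C[C@H](NC(=O)Nc1ccc(F)cc1)c1ccccc1` differs from compound 3 as follows: the two compounds have the same atoms and bonds and differ only in configuration as drawn: 1 of 1 stereo elements differ; a stereocentre at a saturated chain carbon is drawn R in compound 3 and S in compound 4. Within the data shown here, no measured step in this assay touches configuration, so the step carries no precedent here. For compound 4 the expected step is a number 4 percentage points lower from compound 3 to compound 4 (within the scatter), none beyond the scatter, since compound 3 sits at 92%. Compound 4 is therefore estimated at 88%, within 70% to 100%.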

Compound 4, a percentage reported as activity, at one concentration (the size of the read-out at that concentration, not a potency): 85%
Beside the measured number, compound 4's estimate is 3 percentage points above it; measured number inside the range.
By their numbers in this assay, from the lowest: compound 1; then compounds 4, 2 and 3 (each within the scatter of the next).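

In this assay, inverting the stereocentre at the saturated chain carbon gives a number 7 percentage points lower from compound 3 to compound 4 (within the scatter) and so shows no configuration effect beyond the scatter at this position, in a comparison that isolates this one change: the fact that compounds 3 and 4 differ only in the configuration as drawn. Fluoro in place of ethoxycarbonyl on an aromatic carbon gives a number 7 percentage points lower from compound 2 to compound 4 (within the scatter) and leaves those two compounds within the scatter. Fluoro in place of butyl on an aromatic carbon gives a number 25 percentage points higher from compound 1 to compound 4 (beyond the scatter) and so keeps compound 1 apart from compound 4 despite the configuration swap.

As far as these compounds go, whether configuration matters equally with butyl on the aromatic carbon remains open. So does the reading for a longer chain or a carboxylic acid there.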